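Indolylamino pyridopyrimidinone sulfones: benzyl to aryl sulfone

A few compounds are considered here, and "the series" means these few. Any claim that something is new, unique, unknown or untested is made for them only; others in the source may bear on it.

Measured so far:
compound 1 `COc1ccc(Nc2ncc3cc(S(=O)(=O)c4ccc(C)cc4)c(=O)n(C)c3n2)cc1` — 100000 nM
compound 2 `CCCn1c(=O)c(S(=O)(=O)c2ccc(F)cc2F)cc2cnc(Nc3ccc4[nH]ccc4c3)nc21` — 1000 nM
compound 3 `Cn1c(=O)c(S(=O)(=O)Cc2ccc(F)cc2)cc2cnc(Nc3ccc4[nH]ccc4c3)nc21` — 30000 nM

In a functional assay on DU-145 cells (Homo sapiens) for inhibition, read by trypan blue exclusion, with a stated time of 72 h (on this read-out lower numbers stand for stronger inhibition and higher numbers for weaker inhibition), compound 3 gives 30000 nM, the second highest of the three numbers. Its nearest neighbour is compound 1 with 100000 nM, a gap beyond the scatter; the furthest is compound 2 with 1000 nM, a far larger gap, also beyond the scatter. Within the data shown here, no single-point step between the measured compounds exists, so these gaps mix several changes at once and carry no separate attribution.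

The next compound, compound 4 `Cn1c(=O)c(S(=O)(=O)c2ccc([N+](=O)[O-])cc2F)cc2cnc(Nc3ccc4[nH]ccc4c3)nc21`, differs from compound 3 in one place:
2-fluoro-4-nitrophenyl in place of 4-fluorobenzyl on a sulfonyl sulfur

Compound 2, whose number is the lowest shown, also bears a six-membered aromatic ring directly on the sulfonyl sulfur rather than a benzyl group, though it differs from compound 4 elsewhere as well, so the comparison is indirect. On that basis the step from compound 3 to compound 4 is expected to be a decrease in this assay beyond the scatter, a 10-fold lower number from compound 3 to compound 4 (1.00 log units; beyond the scatter), with the size uncertain. Compound 4 is estimated at 3000 nM, within a range of 500 nM to 20000 nM.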

Compound 4, half-maximal inhibitory concentration: 400 nM
Beside the measured number, compound 4's estimate is 7.5-fold (0.88 log units) above it, outside the stated range (below it).
By their numbers in this assay, from the lowest: compound 4; then compound 2; then compound 3; then compound 1.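

In this assay, setting 2-fluoro-4-nitrophenyl in place of 4-fluorobenzyl on the sulfonyl sulfur gives a 75-fold lower number from compound 3 to compound 4 (1.88 log units; beyond the scatter), so the group on the sulfur can by itself move this number by a large margin while the rest of the molecule stays the same. Among these compounds, this is the first comparison that isolates one place, as the gaps among the earlier compounds mixed several changes and could not be assigned to the sulfonyl substituent. The data shown offer no measurement that accounts for the size of this step.

The step changes two things at once, the benzyl link to the sulfur and the substituents on the ring, and the compounds shown do not separate the contribution of each. Still open, from the compounds shown here alone, are how a plain phenyl or a 4-fluorophenyl on the sulfonyl sulfur would read, and whether an amine or a nitrile in place of the nitro group would hold the number of compound 4 at 400 nM.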